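Replacing the hydroxycarbamoyl chain at the assay limit

The source may report more compounds than this note shows. Statements on the series, on what has been measured and on what is new or still open speak of the compounds shown alone.

In a functional assay on HCT-116 cells (Homo sapiens) for antiproliferative activity, read by sulforhodamine B assay, with a stated time of 72 h (on this read-out lower numbers stand for stronger inhibition and higher numbers for weaker inhibition), compound 1 `Cn1cc(-c2ccc(=O)n(CCOc3ccnc4cc(OCCCCCC(=O)NO)ccc34)n2)cn1` gives > 10000 nM and that is a limit, not a number. The same read-out leaves compound 2 `Cn1cc(-c2ccc(=O)n(CCOc3ccnc4cc(OCc5ccc(/C=C/C(=O)Nc6ccccc6N)cc5)ccc34)n2)cn1` at > 10000 nM and that too is a limit, not a number. Going by the values given here, the series so far offers only the limit of > 10000 nM in this assay, at which 2 of the 2 values shown sit, and no measured step between compounds.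

Compound 3 `Cn1cc(-c2ccc(=O)n(CCOc3ccnc4cc(C(=O)Nc5ccccc5N)ccc34)n2)cn1` differs from compound 1 at one place, with (2-aminophenyl)carbamoyl in place of (5-(hydroxycarbamoyl)pentyl)oxy on an aromatic carbon. The counted difference is (2-aminophenyl)carbamoyl in place of (5-(hydroxycarbamoyl)pentyl)oxy on an aromatic carbon and the site lies on a six-membered aromatic ring of carbon only, part of a fused or bridged system of two rings.

The expectation leans on compound 2, which also carries a 2-aminophenyl amide and stays at its limit of > 10000 nM in this assay without a number. No step beyond the usual scatter is expected, in either direction, and the estimated step that the limit leaves unreadable from compound 1 to compound 3 is an expected figure only. Compound 3 is estimated at 12000 nM with an expected range from 4000 nM to 30000 nM and a report as a bare limit is the likeliest outcome.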

Compound 3, half-maximal inhibitory concentration: > 10000 nM
Compound 3 was reported as a limit; the forecaster's own chance of this, stated with the estimate: 75%; the middle value does not contradict the limit.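

In this assay compound 3 gives > 10000 nM, which is a limit and not a number. Going by these compounds alone, compound 1 also stands at a limit, so no step from compound 1 to compound 3 can be read. The compounds shown leave open which groups on the shared core, if any, would give a readable value in this assay: the limit of > 10000 nM in this assay, at which 3 of the 3 values shown sit.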